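The compounds below may be only part of what the source reports. "The series", "measured", "known", "first", "only" and "open" are said of these compounds alone.

Compound 1, `O=C(NC(=S)Nc1nc2cc(Br)ccc2s1)N1CCOCC1`, measured in a functional assay on MCF7 cells (Homo sapiens) for cytotoxicity, read by MTT assay, with a stated time of 24 h; a lower number here means a stronger inhibitor, a higher number a weaker inhibitor: 18100 nM
Compound 2, `O=C(NC(=S)Nc1nc2ccccc2s1)N1CCOCC1`, in this assay: 29300 nM
Compound 3, `O=C(NC(=S)Nc1nc2cc(Br)ccc2s1)c1ccc([N+](=O)[O-])cc1`, in this assay: 32400 nM

All three numbers lie close together, each within the usual scatter of the others, so none of the three can be called stronger or weaker than the rest. Compound 1 and compound 2 share a core and differ in a single place: hydrogen in place of bromo on an aromatic carbon. That change gave a 1.6-fold higher number from compound 1 to compound 2 (0.21 log units; within the scatter). Compound 3 carries a different group on the core of compound 1; the difference between the two cores is not broken down here.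

Compound 4, `O=C(NC(=S)Nc1nc2ccccc2s1)c1ccc([N+](=O)[O-])cc1`, has not yet been measured. It differs from compound 3 in one place: hydrogen in place of bromo on an aromatic carbon. The description of the place matches, word for word, the place of the change from compound 1 to compound 2, so this is the same change, now made on the core of compound 3 rather than the core of compound 1. Going by the values given here, the only guide to its likely effect is that single earlier example, which was small and within the scatter. A step of similar size is therefore expected in this assay, a 1.4-fold higher number from compound 3 to compound 4 (0.14 log units; within the scatter), because the same change earlier gave a 1.6-fold higher number from compound 1 to compound 2 (0.21 log units; within the scatter). Since compound 3 already sits at a weak level, there is some chance that the measurement for compound 4 will be reported only as a limit rather than a number. Compound 4 is expected to give 45000 nM, with a likely range from 20000 nM to 100000 nM.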

Compound 4, half-maximal inhibitory concentration: 33800 nM
For compound 4 the middle estimate is 1.3-fold (0.12 log units) above the measured one; low and high end bracket the measured number.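

In this assay, putting hydrogen in place of bromo on the core of compound 3 gave a 1.0-fold higher number from compound 3 to compound 4 (0.02 log units; within the scatter) and so did not move the number beyond the usual scatter of repeated measurements. Set beside the earlier example of the same change, the two steps agree: the same change on two cores in this assay, a 1.6-fold higher number (0.21 log units; within the scatter) from compound 1 to compound 2 and a 1.0-fold higher number (0.02 log units; within the scatter) from compound 3 to compound 4, 1.6-fold (0.19 log units) apart, within the scatter of two such steps. In this small series, then, the exchange of bromo for hydrogen behaved alike on both cores, with neither step large enough to stand out from the scatter, but two such small steps do not show that the bromo has no effect at all, nor do they give a reliable size for the change or show that it would carry over to any further core.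

The compounds shown have only bromo or hydrogen at this place on the aromatic ring, so it remains open whether a different group there, such as a methoxy group, an amine or a carboxylic acid, would shift the number beyond the scatter. As far as these compounds go, it also remains open whether the same agreement between the two cores would hold on a third core, for instance one carrying a longer chain, or in cells other than those tested here.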